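Benzylic substituent changes on the shared core

The compounds below may be only part of what the source reports. "The series", "measured", "known", "first", "only" and "open" are said of these compounds alone.

Measured so far in a functional assay on MCF7 cells (Homo sapiens) for cytotoxicity, read by neutral red uptake, with a stated time of 3 days; a higher number here means a weaker inhibitor, a lower number a stronger inhibitor:
compound 1 `Nc1ccc(-c2cc(=O)c3c(N)c(F)c(CO)c(F)c3o2)cc1F`: 62 nM
compound 2 `Nc1ccc(-c2cc(=O)c3c(N)c(F)c(C(=O)O)c(F)c3o2)cc1F`: a limit of the assay, > 10000 nM
compound 3 `CCCCCCOCc1c(F)c(N)c2c(=O)cc(-c3ccc(N)c(F)c3)oc2c1F`: 7100 nM

Compound 3 stands highest of the two numbers given; compound 2 sits at the limit of > 10000 nM in this assay, at which 1 of the 3 values shown sits. The step of a 110-fold higher number from compound 1 to compound 3 (2.06 log units; beyond the scatter) is the one that bears here, as compound 4 `NCc1c(F)c(N)c2c(=O)cc(-c3ccc(N)c(F)c3)oc2c1F` is reached from compound 3 by amino in place of hexyloxy on a saturated chain carbon bound to an aromatic carbon, which removes the hexyl chain that the step added. Compound 1 also shows that the hydroxymethyl variant carries a low number, whereas an at least 160-fold higher number from compound 1 to compound 2 (2.20 log units; beyond the scatter) went the other way. Compound 4 is therefore expected to show a 47-fold lower number from compound 3 to compound 4 (1.68 log units; beyond the scatter), a large drop in this assay, with compound 4 estimated at 150 nM (range 30 nM to 1500 nM).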

Compound 4, half-maximal inhibitory concentration: 26 nM
Compound 4: middle estimate off by 5.8-fold (0.76 log units), on the high side; measured number outside the range, below it.
By their numbers in this assay, from the lowest: compound 4; then compound 1; then compound 3. At a limit, above all of these: compound 2.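

In this assay, a low number at this position does not depend on the hydroxy of compound 1: aminomethyl goes further, with a 2.4-fold lower number from compound 1 to compound 4 (0.38 log units; beyond the scatter), a modest step. The amino group also more than recovers the loss seen with the hexyl ether, with a 270-fold lower number from compound 3 to compound 4 (2.44 log units; beyond the scatter). Compound 2 stands at a limit of the assay, so an at least 380-fold lower number from compound 2 to compound 4 (2.58 log units; beyond the scatter) gives only a floor: the limit of > 10000 nM in this assay, at which 1 of the 4 values shown sits.

From the compounds shown here alone, what remains open is whether the low number needs a primary amine. An N-methylaminomethyl, a dimethylaminomethyl, an acetamidomethyl or a longer aminoethyl chain at this place would test that.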